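The source may report more compounds than this note shows. Statements on the series, on what has been measured and on what is new or still open speak of the compounds shown alone.

Values in an ADME assay on HEK293 cells (Homo sapiens) for cytotoxicity, with a stated time of 72 h (on this read-out higher numbers stand for an effect only at larger amounts of compound and lower numbers for an effect already at smaller amounts), so far
compound 1 `Cc1cc(NC(=O)Nc2ccccc2N)c2ccccc2n1` gives > 25000 nM
compound 2 `Cc1cc(NC(=O)Nc2cccc(F)c2)c2ccccc2n1` gives > 25000 nM
compound 3 `Cc1cc(NC(=O)Nc2ncccc2C)c2ccccc2n1` gives > 25000 nM

Compound 1 stands at > 25000 nM as a limit of the assay and not a number. Among the measured compounds shown here, the whole series so far sits at the limit of > 25000 nM in this assay, at which 3 of the 3 values shown sit, and compound 1 has no readable place within it. The change to compound 4 `Cc1cc(NC(=O)Nc2ccccc2C(F)(F)F)c2ccccc2n1` is counted as trifluoromethyl in place of amino on an aromatic carbon and puts trifluoromethyl in place of amino on an aromatic carbon, ortho to a large group. The measured steps that bear on it are a step that the two limits leave unreadable from compound 1 to compound 2 and a step that the two limits leave unreadable from compound 1 to compound 3 and both also remove the 2-aminophenyl group. Their sizes cannot be read, and the same holds for a step that the two limits leave unreadable from compound 2 to compound 3 as well. No step beyond the scatter is therefore expected in this assay and the expected step is a step that the limit leaves unreadable from compound 1 to compound 4 with another limit reading the likeliest result. For compound 4 the estimated value is 28000 nM with an expected range from 14000 nM to 50000 nM on the same read-out.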

Compound 4, half-maximal effective concentration: > 25000 nM
Compound 4: no number, only a limit; the forecaster's own chance of this, stated with the estimate: 85%; the middle value lies beyond the limit too.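

In this assay, among the compounds shown here, compound 4 gives > 25000 nM, a limit of the assay and not a number, so no step from compound 1 to compound 4 can be read. The compounds shown leave open whether the groups on the amide-type nitrogen differ at all in this read-out: the limit of > 25000 nM in this assay, at which 4 of the 4 values shown sit.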